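The compounds below may be only part of what the source reports. "The series", "measured", "known", "first", "only" and "open" are said of these compounds alone.

In a functional assay on HCT-116 cells (Homo sapiens) for antiproliferative activity, read by MTT assay, with a stated time of 48 h (on this read-out higher numbers stand for weaker inhibition and lower numbers for stronger inhibition), compound 1 `CCCCCCCC(CCO)n1cnc2c(Cl)ncnc21`, which carries chloro on an aromatic carbon, gives 4160 nM. Compound 2 `CCCCCCCC(CCO)n1cnc2c(N(C)C)ncnc21`, with dimethylamino there, reads > 50000 nM, which is a limit of the assay and not a number. Compound 3 `CCCCCCCC(CCO)n1cnc2c(N)ncnc21`, with amino there, reads > 50000 nM, also a limit. Replacing chloro with dimethylamino gives an at least 12-fold higher number from compound 1 to compound 2 (1.07 log units; beyond the scatter), and replacing it with amino gives an at least 12-fold higher number from compound 1 to compound 3 (1.07 log units; beyond the scatter). Both steps are large, and they leave compound 2 at the limit of > 50000 nM in this assay, at which 2 of the 3 values shown sit.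

Compound 4 `CCCCCCCCCC(CCO)n1cnc2c(N(C)C)ncnc21` keeps the dimethylamino group and changes the chain instead: ethyl in place of hydrogen on a saturated chain carbon, eight bonds along the chain from an aromatic nitrogen. Neither large step touches the chain, so the data offer no direct measure of this change. Compound 2 gives only a limit, so any gain would have to start from an unknown number. A small move toward stronger inhibition is possible, but the expected step, an at least 1.2-fold lower number from compound 2 to compound 4 (0.09 log units; that floor lies within the scatter), is none beyond the scatter in this assay. For compound 4 the estimated value is 40000 nM, with an expected range from 12000 nM to 70000 nM.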

Compound 4, half-maximal inhibitory concentration: 9810 nM
Compound 4: middle estimate off by 4.1-fold (0.61 log units), on the high side, and the stated range ends above it.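

In this assay, the chain proves to be a place where a change can be read: ethyl in place of hydrogen on a saturated chain carbon, eight bonds along the chain from an aromatic nitrogen, gives an at least 5.0-fold lower number from compound 2 to compound 4 (0.70 log units; beyond the scatter). The earlier compounds shown here differed only on the aromatic carbon, so they could not show that a dimethylamino compound can reach a measured value once its chain changes. Only a floor can be given for this step, because compound 2 rests on a limit and not a number: the limit of > 50000 nM in this assay, at which 2 of the 4 values shown sit.

Going by these compounds, whether a still longer chain would extend this shift remains open, as does whether the same ethyl change would shift compound 1 or compound 3. A methoxy group on that aromatic carbon also remains untested among the compounds shown.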